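Swapping Fluoro for Methyl on an Aromatic Carbon

A few compounds are considered here, and "the series" means these few. Any claim that something is new, unique, unknown or untested is made for them only; others in the source may bear on it.

Measured in a functional assay on MDA-MB-231 cells (Homo sapiens) for inhibition, read by MTT assay, with a stated time of 72 h; a higher number here means a weaker inhibitor, a lower number a stronger inhibitor:
- compound 1 `O=C1N/C(=N/c2nc3cc(-c4ccc(Cl)cc4)sc3s2)S/C1=C/c1ccc2ccccc2c1`: > 50000 nM (a limit)
- compound 2 `O=C1N/C(=N/c2nc3cc(-c4ccc(Cl)cc4)sc3s2)S/C1=C/c1ccc(F)cc1`: 24700 nM

Compound 1 gives > 50000 nM, which is a limit of the assay and not a number. For the measured compounds named here, that leaves compound 2, at 24700 nM, as the only actual number so far in this assay.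

Compound 3 `Cc1ccc(/C=C2/S/C(=N\c3nc4cc(-c5ccc(Cl)cc5)sc4s3)NC2=O)cc1` keeps the shared core of compound 2 and differs in one group: methyl in place of fluoro on an aromatic carbon. In words, this is methyl in place of fluoro on an aromatic carbon, para to a large group.

Going by the values given here, only one measured step bears on this change: an at least 2.0-fold lower number from compound 1 to compound 2 (0.30 log units; that floor lies within the scatter). It is a different swap, and its size is only a floor within the scatter, so it offers weak guidance. The expected 1.1-fold higher number from compound 2 to compound 3 (0.05 log units; within the scatter) is small, with no change beyond the scatter and no favoured direction. For compound 3 the estimated value is 28000 nM, with an expected range from 12000 nM to 50000 nM.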

Compound 3, half-maximal inhibitory concentration: 22800 nM
The estimate for compound 3 lay 1.2-fold (0.09 log units) above the measured number; the measured number falls inside the stated range.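

Swapping fluoro for methyl on this aromatic carbon, para to a large group, gives a 1.1-fold lower number from compound 2 to compound 3 (0.03 log units; within the scatter) in this assay, so the two groups cannot be told apart here. Compared with naphthalen-2-yl, 4-methylphenyl gives an at least 2.1-fold lower number from compound 1 to compound 3 (0.34 log units; beyond the scatter), the first step from compound 1 shown to lie beyond the scatter. That step is only a floor, because compound 1 stands at a limit: the limit of > 50000 nM in this assay, at which 1 of the 3 values shown sits.

The compounds shown leave open whether any group at this position can shift the number beyond the scatter, for instance an amine, a hydroxyl or a carboxylic acid. They also leave open whether fluoro and methyl would still match if the 4-chlorophenyl group elsewhere on the shared core were replaced.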